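Amino in Place of Chloro: An Expectation for Compound 4

The source may report more compounds than this note shows. Statements on the series, on what has been measured and on what is new or still open speak of the compounds shown alone.

Of the compounds shown here, three have been measured in a functional assay on OVCAR-8 cells (Homo sapiens) for cytotoxicity, read by sulforhodamine B assay, with a stated time of 48 h; a higher number here means a weaker inhibitor of growth, a lower number a stronger inhibitor of growth. Compound 3 `ClCc1ccc(Cn2cnc3c(Cl)nc(Cl)nc32)cc1` gives 38000 nM, and compound 1 `Nc1nc(Cl)c2ncn(Cc3ccc(CCl)cc3)c2n1` gives 33100 nM. The change between them, (amino in place of chloro on an aromatic carbon), made a step of a 1.1-fold lower number from compound 3 to compound 1 (0.06 log units; within the scatter). Compound 2 `ClCc1cccc(Cn2cnc3c(Cl)nc(Cl)nc32)c1` gives 3540 nM, the lowest of the three numbers; compound 1 is the nearest and compound 3 the furthest, and both gaps lie beyond the scatter. Compound 2 and compound 3 are built from the same atoms joined differently, and the difference between the two cores is not broken down here.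

Compound 4 `Nc1nc(Cl)c2ncn(Cc3cccc(CCl)c3)c2n1` has not yet been measured. It differs from compound 2 by amino in place of chloro on an aromatic carbon, which is the same change as the one from compound 3 to compound 1, the place descriptions agreeing word for word; among the compounds shown the change occurs in two places in all. For the measured compounds named here, because the one measured instance of this change gave a 1.1-fold lower number from compound 3 to compound 1 (0.06 log units; within the scatter), compound 4 is expected to sit close to compound 2 in this assay, with an expected step of a 1.0-fold lower number from compound 2 to compound 4 (0.02 log units; within the scatter). The estimate for compound 4 is therefore 3400 nM, with a range from 1400 nM to 8500 nM, kept fairly wide since the expectation rests on a single measured instance of the change.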

Compound 4, concentration for total growth inhibition: 6760 nM
Compound 4: the middle estimate sits 2.0-fold (0.30 log units) below what was measured; the measured number falls inside the stated range.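

In this assay, amino in place of chloro on an aromatic carbon, the carbon between two ring nitrogen atoms, gives a 1.9-fold higher number from compound 2 to compound 4 (0.28 log units; within the scatter) on the core of compound 2, so this second instance also stays within the scatter. Set beside the first instance, the change behaves alike on both cores, with no difference between the two steps that can be told from the scatter: the same change on two cores in this assay, a 1.1-fold lower number (0.06 log units; within the scatter) from compound 3 to compound 1 and a 1.9-fold higher number (0.28 log units; within the scatter) from compound 2 to compound 4, 2.2-fold (0.34 log units) apart, within the scatter of two such steps. For the compounds shown here, this shows that, on these two cores, the exchange of chloro for amino carried over without a step beyond the scatter, but it rests on only two pairs, shows no clear effect of the change in either of them, and does not show that the same would hold on any other core.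

The compounds shown leave open whether another group on that same carbon, such as a methylamino group, a methoxy group or a plain hydrogen, would give a step beyond the scatter on either core. They also leave open whether the change would carry over in the same way if the chloromethyl group gave way to a hydroxymethyl group or a longer chain such as chloroethyl.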